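Extending Compound 1 at the Ring Nitrogen: Expected Tolerability

The source may report more compounds than this note shows. Statements on the series, on what has been measured and on what is new or still open speak of the compounds shown alone.

Compound 1 `CC(C)OC(=O)c1sc(Nc2ncccn2)nc1-c1cnccn1` was tested in a toxicity assay on PH5CH cells (Homo sapiens) for cytotoxicity, read by MTT assay, with a stated time of 72 h (a higher number here means that more compound is tolerated, a lower number that less compound is tolerated), where compound 1 gives 50000 nM. Its closest relative, compound 2 `CC(C)OC(=O)c1sc(Nc2ncccn2)nc1-c1ccncn1`, gives 50000 nM in this assay, so compound 1 stands level with compound 2 at the digits shown. For the measured compounds named here, the one step available, no change at the digits printed from compound 1 to compound 2 (within the scatter), exchanges one aromatic ring for another and leaves the read-out unchanged within the scatter. The unmeasured compound 3 `CC(C)OC(=O)OCN(c1ncccn1)c1nc(-c2cnccn2)c(C(=O)OC(C)C)s1` differs from compound 1 in another way: ((isopropoxycarbonyl)oxy)methyl in place of hydrogen on a nitrogen on an aromatic ring. Going by the values given here, no measured step touches this ring nitrogen, so the step from compound 1 to compound 2 bears on it only by showing that the shared core can be altered without moving in this assay. The expected step is therefore none beyond the scatter, a 1.1-fold lower number from compound 1 to compound 3 (0.05 log units; within the scatter). Compound 3 is estimated to give 45000 nM in this assay, with a range from 15000 nM to 100000 nM.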

Compound 3, half-maximal cytotoxic concentration: 50000 nM
Compound 3: the middle estimate sits 1.1-fold (0.05 log units) below what was measured; the range from low to high includes it.
By their numbers in this assay, from the lowest: compounds 1, 2 and 3 (each within the scatter of the next).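

In this assay, putting ((isopropoxycarbonyl)oxy)methyl in place of hydrogen on a nitrogen on an aromatic ring gives no change at the digits printed from compound 1 to compound 3 (within the scatter) and so adds a second kind of change to the picture. The earlier step only exchanged one aromatic ring for another, whereas this one shows that the nitrogen, which carries hydrogen in compound 1 and compound 2, can take a much larger group with no shift in this read-out. Nothing available explains why the read-out stays the same.

From the compounds shown here alone, it remains open whether other groups on this nitrogen, such as a plain methyl, an acetyl or a longer chain ending in an amine, would behave the same way. The compounds shown also leave open what a carboxylic acid in place of the isopropyl ester would do.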